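This account rests on a few compounds, and the source may have more. Where it says the series, first, only, none or still open, it means among the compounds named here.

Measured in a functional assay on HL-60 cells (Homo sapiens) for inhibition, read by resazurin assay, with a stated time of 72 h; a lower number here means a stronger inhibitor, a higher number a weaker inhibitor:
compound 1 `COc1ccc(C2C(O)C(=O)N2c2cc(OC)c(OC)c(OC)c2)cc1`: 13 nM
compound 2 `CCSc1ccc(C2C(Oc3ccccc3)C(=O)N2c2cc(OC)c(OC)c(OC)c2)cc1`: 508 nM
compound 3 `CCOc1ccc(C2C(C3CC3)C(=O)N2c2cc(OC)c(OC)c(OC)c2)cc1`: 201 nM

Among these three, compound 3, at 201 nM, holds the middle place. Its number is lower than that of compound 2 and higher than that of compound 1, beyond the scatter in both cases. Compound 4 `COc1ccc(C2C(C3CC3)C(=O)N2c2cc(OC)c(OC)c(OC)c2)cc1` has not yet been measured. It differs from compound 3 in one place: hydrogen in place of methyl on a saturated chain carbon bound to an oxygen on an aromatic ring, which turns 4-ethoxyphenyl into 4-methoxyphenyl. Among the compounds with values here, no measured pair isolates this change. Compound 1, at 13 nM, carries the same 4-methoxyphenyl but differs elsewhere too, so it is only a loose guide. A move to a lower number in this assay, probably beyond the scatter, is expected. The expected change is a 4.5-fold lower number from compound 3 to compound 4 (0.65 log units; beyond the scatter). The estimate for compound 4 is 45 nM, with an expected range from 12 nM to 170 nM.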

Compound 4, half-maximal inhibitory concentration: 156 nM
The estimate for compound 4 lay 3.5-fold (0.54 log units) below the measured number, within the range that was stated.
By their numbers in this assay, from the lowest: compound 1; then compounds 4 and 3 (each within the scatter of the next); then compound 2.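

In this assay, hydrogen in place of methyl on a saturated chain carbon bound to an oxygen on an aromatic ring gives a 1.3-fold lower number from compound 3 to compound 4 (0.11 log units; within the scatter), so with cyclopropyl held fixed, 4-ethoxyphenyl and 4-methoxyphenyl are not told apart. With 4-methoxyphenyl held fixed, cyclopropyl in place of hydroxy on a saturated ring carbon gives a 12-fold higher number from compound 1 to compound 4 (1.08 log units; beyond the scatter), a large step at that ring carbon. No evidence at hand accounts for either step. Open, as far as these compounds go, is whether a longer chain such as propoxy would keep this number, and how an amine would compare with hydroxy and cyclopropyl on that ring carbon.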